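Moving the Bromine on the Benzyl Arm of Compound 1

This account rests on a few compounds, and the source may have more. Where it says the series, first, only, none or still open, it means among the compounds named here.

In a functional assay on A549 cells (Homo sapiens) for cytotoxicity, read by MTT assay, with a stated time of 48 h (on this read-out lower numbers stand for stronger inhibition and higher numbers for weaker inhibition), compound 1 `O=c1ccoc2cc(OCc3cn(Cc4cccc(Br)c4)nn3)ccc12` gives only a limit, > 100000 nM. Compound 2 `O=c1ccoc2cc(OCc3cn(Cc4cccc(F)c4)nn3)ccc12` likewise reaches only a limit, > 100000 nM. Compound 3 `O=c1ccoc2cc(OCc3cn(Cc4ccccc4F)nn3)ccc12` does give a number, 10800 nM. Because compound 1 and compound 2 both sit at the limit of > 100000 nM in this assay, at which 2 of the 3 values shown sit, the step that the two limits leave unreadable from compound 1 to compound 2 cannot be read. Compound 4 `O=c1ccoc2cc(OCc3cn(Cc4ccccc4Br)nn3)ccc12` has not yet been measured; it differs from compound 1 by 2-bromophenyl in place of 3-bromophenyl on a saturated chain carbon bound to an aromatic nitrogen. The measured steps that bear on this change, each moving a halogen from a 3-substituted to a 2-substituted benzyl, are an at least 9.2-fold lower number from compound 1 to compound 3 (0.96 log units; beyond the scatter) and an at least 9.2-fold lower number from compound 2 to compound 3 (0.96 log units; beyond the scatter). A step in the same direction is therefore expected, an at least 8.3-fold lower number from compound 1 to compound 4 (0.92 log units; beyond the scatter). Compound 4 is estimated at 12000 nM, with a range of 4000 nM to 60000 nM.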

Compound 4, half-maximal inhibitory concentration: > 100000 nM
Compound 4 ended at the assay's limit; the forecaster's own chance of this, stated with the estimate: 30%; middle value at least 8.3-fold (0.92 log units) away from the limit.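

Bromo in place of fluoro on the ring gives an at least 9.2-fold higher number from compound 3 to compound 4 (0.96 log units; beyond the scatter), so the activity seen with the 2-fluorophenyl arm does not carry over to the 2-bromophenyl arm. Moving a halogen to this ring position therefore does not give a measurable number by itself; the halogen matters too. The steps from compound 1 and compound 2 to compound 4 cannot be read, since all three compounds sit at one limit: the limit of > 100000 nM in this assay, at which 3 of the 4 values shown sit.

As far as these compounds go, how a 2-chlorobenzyl or 2-methoxybenzyl arm would behave remains open. So does how far compound 1, compound 2 and compound 4 lie beyond that limit.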